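The compounds below may be only part of what the source reports. "The series", "measured", "known", "first", "only" and "open" are said of these compounds alone.

Working notes on the series, read in a functional assay on A-375 cells (Homo sapiens) for antiproliferative activity; a lower number here means a stronger inhibitor, a higher number a weaker inhibitor. Compound 1 `O=C(Nc1ccc(-c2cscn2)cc1)C1CCCN(Cc2ccc(F)c(F)c2)C1`, with 3,4-difluorobenzyl on the amine nitrogen in a ring, gives 880 nM. Compound 3 `O=C(Nc1ccc(-c2cscn2)cc1)C1CCCN(Cc2cccc(F)c2F)C1`, with 2,3-difluorobenzyl at that place, gives 1480 nM. Among the measured compounds shown here, the measured step, a 1.7-fold higher number from compound 1 to compound 3 (0.23 log units; within the scatter), leaves compound 3 level with the only other number in the set. Compound 2 `O=C(Nc1ccc(-c2cscn2)cc1)C1CCCN(C(=O)c2ccc(F)c(F)c2)C1`, with (3,4-difluorophenyl)carbonyl at that place, reads > 20000 nM, which is a limit of the assay and not a number. The step of an at least 22-fold higher number from compound 1 to compound 2 (1.35 log units; beyond the scatter) concerns the benzyl group, which compound 4 keeps, so it offers no guide here beyond favouring that form.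

Compound 4 `O=C(Nc1ccc(-c2cscn2)cc1)C1CCCN(Cc2ccc(Cl)c(Cl)c2)C1` departs from compound 3 by 3,4-dichlorophenyl in place of 2,3-difluorophenyl on a saturated chain carbon bound to an amine nitrogen in a ring. The closest evidence is the change of the difluorophenyl pattern in a 1.7-fold higher number from compound 1 to compound 3 (0.23 log units; within the scatter). For the measured compounds named here, no measured step replaces fluorine with chlorine, so that part remains untested, and the uncertainty is wide. No step beyond the scatter is expected, in either direction. The expected change is a 1.5-fold lower number from compound 3 to compound 4 (0.17 log units; within the scatter). Compound 4 is estimated at 1000 nM, with an expected range of 300 nM to 3000 nM.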

Compound 4, half-maximal inhibitory concentration: 1730 nM
For compound 4 the middle estimate is 1.7-fold (0.24 log units) below the measured one; the range from low to high includes it.
By their numbers in this assay, from the lowest: compounds 1, 3 and 4 (each within the scatter of the next). At a limit, above all of these: compound 2.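

In this assay, fluorine and chlorine are now compared directly on the 3,4-substituted benzyl group, and the step, a 2.0-fold higher number from compound 1 to compound 4 (0.29 log units; within the scatter), stays within the scatter. The second step, a 1.2-fold higher number from compound 3 to compound 4 (0.07 log units; within the scatter), is also within the scatter, so this position tolerates both the change of halogen and the change of pattern, with compound 1, compound 3 and compound 4 on one level. The gap to the carbonyl form also holds with chlorine, an at least 11-fold lower number from compound 2 to compound 4 (1.06 log units; beyond the scatter), though this step rests on the limit of compound 2, which is not a number: the limit of > 20000 nM in this assay, at which 1 of the 4 values shown sits.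

On these data alone, whether unsubstituted benzyl, methoxybenzyl or a longer chain such as phenethyl on the amine nitrogen in a ring stays on this level remains open. Also open, as far as these compounds go, is how an amine or a carboxylic acid on the shared core would read.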